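The compounds below may be only part of what the source reports. "The series", "measured", "known", "first", "only" and "open" are said of these compounds alone.

Measured so far in a functional assay on HCT-116 cells (Homo sapiens) for inhibition, read by CCK-8 assay, with a stated time of 48 h; a lower number here means a stronger inhibitor, a higher number a weaker inhibitor:
- Compound 1 `COc1ccc(CN(C(=O)CSC(=S)N2CCN(C)CC2)c2cc(OC)c(OC)c(OC)c2)cc1`: 2640 nM
- Compound 2 `COc1ccc(CN(C(=O)CSC(=S)N2CCc3ccccc32)c2cc(OC)c(OC)c(OC)c2)cc1`: 7710 nM
- Compound 3 `COc1ccc(CN(C(=O)CSC(=S)N2CCCc3cc(C)ccc32)c2cc(OC)c(OC)c(OC)c2)cc1`: 5230 nM

Compound 3, at 5230 nM, lies within the scatter of both other compounds: the data show a 2.0-fold higher number from compound 1 to compound 3 (0.30 log units; within the scatter) and a 1.5-fold lower number from compound 2 to compound 3 (0.17 log units; within the scatter). Only a 2.9-fold higher number from compound 1 to compound 2 (0.47 log units; beyond the scatter) goes beyond the scatter, and it is modest.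

Compound 4 `COc1ccc(CN(C(=O)CSC(=S)N2CCCc3cc(OC)ccc32)c2cc(OC)c(OC)c(OC)c2)cc1` differs from compound 3 in a single place, with methoxy in place of methyl on an aromatic carbon.

Within the data shown here, no measured step tests this exchange. All three replace the whole group on the thiocarbonyl carbon, so they bear on it only indirectly, and they show a narrow spread of values. With so little to go on, no step beyond the scatter is expected in this assay, and no direction can be favoured. The estimated change is a 1.0-fold lower number from compound 3 to compound 4 (0.02 log units; within the scatter). Compound 4 is expected at 5000 nM, with an estimated range of 2200 nM to 11000 nM.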

Compound 4, half-maximal inhibitory concentration: > 20000 nM
Compound 4 gave a limit, no number; the forecaster's own chance of this, stated with the estimate: 3%; middle value at least 4.0-fold (0.60 log units) away from the limit.
By their numbers in this assay, from the lowest: compounds 1, 3 and 2 (each within the scatter of the next, the first and the last beyond it). At a limit, above all of these: compound 4.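

In this assay compound 4 gives > 20000 nM, which is a limit of the assay and not a number. Methoxy in place of methyl on an aromatic carbon of the 1,2,3,4-tetrahydroquinolin-1-yl group gives an at least 3.8-fold higher number from compound 3 to compound 4 (0.58 log units; beyond the scatter), so this exchange at a single position lies beyond the scatter, while compound 3 stood within the scatter of both compound 1 and compound 2 despite replacement of the whole group on the thiocarbonyl carbon. The 6-methoxy-1,2,3,4-tetrahydroquinolin-1-yl group also stands apart from the other two groups, with an at least 2.5-fold higher number from compound 2 to compound 4 (0.41 log units; beyond the scatter) and an at least 7.5-fold higher number from compound 1 to compound 4 (0.87 log units; beyond the scatter).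

The compounds shown leave open how a hydroxyl, a fluorine or an ethyl group on the same aromatic carbon would read. They also leave open whether methoxy in place of methyl would give a comparable step on the 2,3-dihydro-1H-indol-1-yl group.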